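The source may report more compounds than this note shows. Statements on the series, on what has been measured and on what is new or still open speak of the compounds shown alone.

Measured in an ADME assay on HEK293 cells (Homo sapiens) for cytotoxicity, read by fluorescence and resazurin assay, with a stated time of 24 h; a lower number here means that less compound is tolerated, a higher number that more compound is tolerated:

Compound 1 `Nc1ccc(-c2nnc(SC3=CS(=O)(=O)c4ccccc43)o2)cc1`: 4000 nM
Compound 2 `COC(=O)c1ccc(-c2nnc(SC3=CS(=O)(=O)c4ccccc43)o2)cc1`: 4000 nM
Compound 3 `O=S1(=O)C=C(Sc2nnc(-c3ccccc3Cl)o2)c2ccccc21`: 4000 nM

In this assay compound 3 gives 4000 nM and stands level with compounds 1 and 2, so none of the three can be ranked above another. The unmeasured compound 4 `COc1ccc(-c2nnc(SC3=CS(=O)(=O)c4ccccc43)o2)cc1` carries 4-methoxyphenyl in place of 2-chlorophenyl on an aromatic carbon of a five-membered aromatic ring with 2 nitrogen and 1 oxygen (4-methoxyphenyl in place of 2-chlorophenyl on an aromatic carbon).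

For the measured compounds named here, two measured steps bear on this change. Methoxycarbonyl in place of amino gave no step beyond the scatter (no change at the digits printed from compound 1 to compound 2 (within the scatter)), and 2-chlorophenyl in place of 4-aminophenyl gave none either (no change at the digits printed from compound 1 to compound 3 (within the scatter)). Going by the values given here, on these two steps, no step beyond the scatter is expected in this assay and neither direction is favoured, though the evidence rests on only three compounds. The expected step is small (no change at the digits printed from compound 3 to compound 4 (within the scatter)). For compound 4 the estimated value is 4000 nM, with an expected range from 2000 nM to 8000 nM.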

Compound 4, half-maximal cytotoxic concentration: 2000 nM
Estimate against measurement, compound 4: 2.0-fold (0.30 log units) above; measured number inside the range.
By their numbers in this assay, from the lowest: compounds 4, 1, 2 and 3 (each within the scatter of the next).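

In this assay, 4-methoxyphenyl on this aromatic carbon stays within the scatter of all three earlier groups: the step is a 2.0-fold lower number from compound 3 to compound 4 (0.30 log units; within the scatter) and against the other two it is a 2.0-fold lower number from compound 2 to compound 4 (0.30 log units; within the scatter) and a 2.0-fold lower number from compound 1 to compound 4 (0.30 log units; within the scatter). The earlier compounds shown here shared one printed value, whereas compound 4 gives the first difference at the digits printed, and that difference is still too small to rank any of the four compounds. No measurement shown here explains these numbers.

From the compounds shown here alone, all four groups at this place are substituted phenyl rings, so the effect of a carboxylic acid, a piperidine or a longer alkyl chain there in this assay remains open. Also open, going by these compounds, is whether any change at this place can produce a step beyond the scatter.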